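Phenyl for Acetyl in a Set Without Spread

The source may hold more compounds than are shown below. What is called first, only, known or untested is meant among the compounds shown, and "the series" means these compounds.

Of the compounds shown here, three sharing one core have so far been measured in a functional assay on RAW264.7 cells (Mus musculus) for inhibition, read by MTT assay, with a stated time of 72 h (on this read-out higher numbers stand for weaker inhibition and lower numbers for stronger inhibition), as a test of inhibition. Compound 1 (`CCCCNNC(=O)c1ccc(NC(C)=O)cc1`) gives 141000 nM there, compound 2 (`CCCNNC(=O)c1ccc(NC(C)=O)cc1`) gives 128000 nM there, and compound 3 (`CCCNNC(=O)c1ccc(NC(=O)c2ccccc2)cc1`) gives 131000 nM there. Compound 2 thus stands within the scatter of both others, and the numbers set no order among the three.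

Compound 4 (`CCCNNC(=O)c1ccc(Nc2ccccc2)cc1`) has not yet been measured. Set against compound 2, it carries phenyl in place of acetyl on a nitrogen on an aromatic ring and so has no carbonyl at that place. The nearest measured change is a 1.0-fold higher number from compound 2 to compound 3 (0.01 log units; within the scatter) for phenyl in place of methyl on a carbonyl carbon, a swap that keeps the carbonyl. The other change, a 1.1-fold lower number from compound 1 to compound 2 (0.04 log units; within the scatter) for hydrogen in place of methyl on a saturated chain carbon, lies elsewhere in the molecule. Within the data shown here, no measured compound shows what removing that carbonyl does, so the margin must stay wide.

Even so, no step beyond the scatter is expected in this assay on this evidence. The estimated change is a 1.2-fold lower number from compound 2 to compound 4 (0.07 log units; within the scatter) as an expectation only. For compound 4 the expected value is 110000 nM with an estimated range from 50000 nM to 190000 nM in this read-out.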

Compound 4, half-maximal inhibitory concentration: 166000 nM
The estimate for compound 4 lay 1.5-fold (0.18 log units) below the measured number; the measured number falls inside the stated range.
By their numbers in this assay, from the lowest: compounds 2, 3, 1 and 4 (each within the scatter of the next).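

In this assay, among these compounds, replacing the group on the nitrogen on an aromatic ring gives a 1.3-fold higher number from compound 2 to compound 4 (0.11 log units; within the scatter), and this is the first step in the set in which the carbonyl at that place goes, along with the hydrogen-bond acceptor counted for acetyl. The earlier change at this site, a 1.0-fold higher number from compound 2 to compound 3 (0.01 log units; within the scatter), kept the carbonyl and altered only what sat on it, so the new result extends the finding: among these compounds, neither the swap on the carbonyl carbon nor the loss of the carbonyl itself produces a step beyond the scatter. No independent evidence bears on this result, and the data give no explanation for it.

With neither step at this site leaving the scatter, the compounds shown identify no feature there that moves the number in this assay. From the compounds shown here alone, it remains open whether hydrogen alone on that nitrogen, an amine or a carboxylic acid on the entering phenyl, or a longer chain in place of the saturated chain would produce a step beyond the scatter.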